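The source may report more compounds than this note shows. Statements on the series, on what has been measured and on what is new or still open speak of the compounds shown alone.

Compounds measured so far:
compound 1, `CC(C)Cc1csc(N)c1C(=O)c1ccc(Cl)cc1`, 1%
compound 2, `CC(C)(C)Cc1csc(N)c1C(=O)c1cccc(Cl)c1`, 2%
compound 3, `CC(C)(C)Cc1c(-c2ccncc2)sc(N)c1C(=O)c1ccc(Cl)cc1`, 1%

All three were tested in an assay on CHO cells for displacement of a labelled ligand from adenosine receptor A1 (Homo sapiens), read by scintillation counting, tested at 10 uM; a higher number here means more inhibition at the concentration tested (going by the name of the read-out), a lower number less inhibition. Compound 3 gives 1%, level with compound 1 at the digits shown and together the lowest of the three numbers; the gap to compound 2 lies within the scatter, so no order among the three can be read off. Among the compounds with values here, every value so far sits at the bottom of the scale.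

The next compound is compound 4, `COc1cccc(-c2sc(N)c(C(=O)c3ccc(Cl)cc3)c2CC(C)(C)C)c1`. It differs from compound 3 by a single change: 3-methoxyphenyl in place of pyridin-4-yl on an aromatic carbon. No step between two measured compounds bears on this change, so there is nothing to calibrate it against; the shared core with a neopentyl group and an amino group has shown no inhibition in this assay at this concentration in either of its three forms. The step from compound 3 to compound 4 is therefore expected to stay within the scatter, a number 2 percentage points higher from compound 3 to compound 4 (within the scatter). For compound 4 the estimate is 3%, with a range from 0% to 15%.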

Compound 4, a percentage reported as inhibition, at one concentration (the size of the read-out at that concentration, not a potency): 1%
Beside the measured number, compound 4's estimate is 2 percentage points above it; the range from low to high includes it.
By their numbers in this assay, from the lowest: compounds 1, 3, 4 and 2 (each within the scatter of the next).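

In this assay, 3-methoxyphenyl in place of pyridin-4-yl on the aromatic carbon next to the ring sulfur gives no change at the digits printed from compound 3 to compound 4 (within the scatter). Within the data shown here, this is the first step that can be read at this position: a larger, carbon-only aromatic ring bearing a methoxy group leaves the number at the bottom of the scale, just as the ring with a nitrogen does. No outside measurement bears on this result.

With both groups at the bottom of the scale, the step cannot show whether this position matters for displacement of the labelled ligand at all. As far as these compounds go, whether a carboxylic acid or a piperazine at this carbon, or an acylated amine in place of the amino group, would lift the number remains open.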